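Swapping nitro for methoxy on the benzyl ring

A few compounds are considered here, and "the series" means these few. Any claim that something is new, unique, unknown or untested is made for them only; others in the source may bear on it.

Measured compounds in a functional assay on SW480 cells (Homo sapiens) for cytotoxicity, read by MTT assay, with a stated time of 48 h; a higher number here means a weaker inhibitor, a lower number a stronger inhibitor:
- compound 1 `Cc1ccc(Cn2cc(COc3ccc4c(=O)ccoc4c3)nn2)cc1`: 10400 nM
- compound 2 `O=c1ccoc2cc(OCc3cn(Cc4cccc(Br)c4)nn3)ccc12`: a limit, > 100000 nM
- compound 3 `O=c1ccoc2cc(OCc3cn(Cc4ccc([N+](=O)[O-])cc4)nn3)ccc12`: 19300 nM

All three share one core and differ only in the substituted phenyl ring hanging from the triazole nitrogen. Compound 3 carries the highest of the two actual numbers in this assay; its nearest neighbour is compound 1, with the step of a 1.9-fold higher number from compound 1 to compound 3 (0.27 log units; within the scatter) sitting within the scatter. For compound 2 this assay gives only a limit, not a number (the limit of > 100000 nM in this assay, at which 1 of the 3 values shown sits). The step of an at least 9.6-fold higher number from compound 1 to compound 2 (0.98 log units; beyond the scatter) is beyond the scatter, as is the step of an at least 5.1-fold lower number from compound 2 to compound 3 (0.71 log units; beyond the scatter).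

Compound 4 `COc1ccc(Cn2cc(COc3ccc4c(=O)ccoc4c3)nn2)cc1` has not yet been measured. It differs from compound 3 by methoxy in place of nitro on an aromatic carbon. Among the measured compounds shown here, the step that bears most directly on this is the one from compound 1 to compound 3, where exchanging one group on the same aromatic carbon left the number within the scatter. The moves that did reach beyond the scatter involved compound 2, where the group and its place on the ring both changed. From this, the expected step is a 1.5-fold lower number from compound 3 to compound 4 (0.17 log units; within the scatter), staying within the scatter. Compound 4 is thus estimated to give 13000 nM, with a likely range from 4500 nM to 40000 nM.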

Compound 4, half-maximal inhibitory concentration: 20400 nM
Estimate against measurement, compound 4: 1.6-fold (0.20 log units) below; the range from low to high includes it.
By their numbers in this assay, from the lowest: compounds 1, 3 and 4 (each within the scatter of the next). At a limit, above all of these: compound 2.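

In this assay, methoxy in place of nitro on the aromatic carbon para to a large group gives a 1.1-fold higher number from compound 3 to compound 4 (0.02 log units; within the scatter), and methoxy in place of methyl gives a 2.0-fold higher number from compound 1 to compound 4 (0.29 log units; within the scatter), so methyl, nitro and methoxy at this place, in compounds 1, 3 and 4, cannot be told apart despite their different atoms and hydrogen-bond acceptor counts. Only the 3-bromophenyl of compound 2 stands apart from this group, now also against the methoxy compound, with an at least 4.9-fold lower number from compound 2 to compound 4 (0.69 log units; beyond the scatter). The value of compound 2 is a limit and not a number: the limit of > 100000 nM in this assay, at which 1 of the 4 values shown sits.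

The compounds shown leave open whether an amine, a carboxylic acid or a longer chain at this same aromatic carbon would also stay within the scatter of these three. They also leave open whether the gap to compound 2 comes from the bromine itself or from its place on the ring, as a 4-bromophenyl compound or a 3-methoxyphenyl compound would separate the two.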